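Amide variation in the series: compound 3 to compound 4

The source may report more compounds than this note shows. Statements on the series, on what has been measured and on what is new or still open speak of the compounds shown alone.

Four compounds share one core and differ only in the amide portion. In an assay on a protein complex for inhibition of CDK8/Cyclin C (Homo sapiens), with a stated time of 1 h (on this read-out lower numbers stand for stronger inhibition and higher numbers for weaker inhibition), compound 1 `CC(C)[C@@H](NC(=O)/C=C/c1ccncc1-c1ccc2ccccc2c1)C(=O)O` is recorded as "not determined" (no result reported), and compound 3 `O=C(O)[C@@H]1CCCN1C(=O)/C=C/c1ccncc1-c1ccc2ccccc2c1` is likewise recorded as "not determined" (no result reported); both carry a carboxylic acid on the amide side. Going by the values given here, the single number in the set comes from compound 2 `COC1CN(C(=O)/C=C/c2ccncc2-c2ccc3ccccc3c2)C1`, which in this assay gives 42.8 nM. Among the compounds with values here, compound 3 therefore stands without a value, alongside one further entry without a value, and no step between two measured compounds can be computed.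

Compound 4 `CN1CCN(C(=O)/C=C/c2ccncc2-c2ccc3ccccc3c2)CC1` is the next entry. Relative to compound 3 the change is 4-methylpiperazin-1-yl in place of 2-carboxypyrrolidin-1-yl on a carbonyl carbon. Within the data shown here, no comparable step is recorded, so the size and direction of this step in this assay cannot be read from the numbers; the only anchor is compound 2, which also lacks the carboxylic acid and gives a value in the tens.

Compound 4 is therefore expected to land near compound 2, at an estimated 60 nM with a range from 15 nM to 250 nM.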

Compound 4, half-maximal inhibitory concentration: 43.6 nM
The estimate for compound 4 lay 1.4-fold (0.14 log units) above the measured number; the measured number falls inside the stated range.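

Going by these compounds alone, replacing 3-methoxyazetidin-1-yl with 4-methylpiperazin-1-yl on a carbonyl carbon gives, in this assay, a 1.0-fold higher number from compound 2 to compound 4 (0.01 log units; within the scatter) and provides the first readable step: at this place, these two different rings cannot be told apart on this read-out. As far as these compounds go, the steps from compound 1 or compound 3 to the other compounds cannot be read, so the effect of the carboxylic acid at this place remains unknown. No measurement bears on why compound 2 and compound 4 match.

Whether the same read-out would hold with an open-chain dimethylamino group or a longer chain ending in a hydroxyl group on the carbonyl carbon is open. Also open, from the compounds shown here alone, is what would follow from an acetyl group in place of the methyl on the piperazine nitrogen.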